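A few compounds are considered here, and "the series" means these few. Any claim that something is new, unique, unknown or untested is made for them only; others in the source may bear on it.

Measured so far:
compound 1 `O=C(NO)c1ccc(NCc2nc(-c3cccs3)nn2-c2ccc(O)cc2)cc1` — 79.6%
compound 2 `Cc1cccc(-n2nc(-c3ccccc3)nc2CNc2ccc(C(=O)NO)cc2)c1` — 66%

In an assay on Sf9 cells for inhibition of protein deacetylase HDAC6 (Homo sapiens), read by fluorescence, with a stated time of 40 min, tested at 100 nM (on this read-out higher numbers stand for more inhibition at the one concentration tested (going by the name of the read-out) and lower numbers for less inhibition), compound 1 gives 79.6%, and compound 2 gives 66%, the lower of the two numbers, a gap beyond the usual scatter. Among the measured compounds shown here, no pair of measured compounds differing in one place is available, so the change to compound 3 `O=C(NO)c1ccc(NCc2nc(-c3ccccc3)nn2-c2ccc(F)cc2)cc1` has no measured counterpart. Compound 3 differs from compound 2 by 4-fluorophenyl in place of 3-methylphenyl on an aromatic nitrogen. In this assay a small upward step is expected, though one within the scatter would not surprise. Compound 3 is expected to give 71%, range 56% to 84%. This expectation means an estimated step of a number 5 percentage points higher from compound 2 to compound 3 (within the scatter).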

Compound 3, a percentage reported as inhibition, at one concentration (the size of the read-out at that concentration, not a potency): 67.6%
Beside the measured number, compound 3's estimate is 3.4 percentage points above it; low and high end bracket the measured number.
By their numbers in this assay, from the lowest: compounds 2 and 3 (each within the scatter of the next); then compound 1.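

In this assay, among the compounds shown here, the change to 4-fluorophenyl from 3-methylphenyl on the aromatic nitrogen gives a number 1.6 percentage points higher from compound 2 to compound 3 (within the scatter) as the first one-place comparison. The numbers on either side of this exchange of one substituted phenyl group for another are therefore level at the one concentration tested. Nothing measured here bears on the reason for this result. Compound 1 differs from compound 3 in more than one place, so its number cannot be assigned to any single change. Going by these compounds, how an amine or a carboxylic acid on this aromatic nitrogen's phenyl ring would read also remains open.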